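From nitro to chloro, close to the assay limit

The source may report more compounds than this note shows. Statements on the series, on what has been measured and on what is new or still open speak of the compounds shown alone.

For the measured compounds named here, compound 2 `O=[N+]([O-])c1ccc(Nc2nccc(-c3ccc(Br)cc3)n2)cc1` is the only compound of this pair with a number rather than a limit: in an assay on isolated protein for inhibition of phosphatidylinositol 4,5-bisphosphate 3-kinase catalytic subunit beta isoform (Homo sapiens) (on this read-out lower numbers stand for stronger inhibition and higher numbers for weaker inhibition), compound 2 gives 961 nM. Compound 1 `Cc1cccc(Nc2nccc(-c3ccc(Br)cc3)n2)c1` reaches only the limit of this assay, where compound 1 gives > 1000 nM. Among the values shown, compound 2 stands just under (the limit of > 1000 nM in this assay, at which 1 of the 2 values shown sits). Compound 3 `Clc1ccc(Nc2nccc(-c3ccc(Br)cc3)n2)cc1` is not yet measured; it differs from compound 2 by chloro in place of nitro on an aromatic carbon, in words chloro in place of nitro on an aromatic carbon. No step between measured compounds is shown, so no measured change of this kind guides the comparison. The step from compound 2 to compound 3 is expected to be small, in either direction or none beyond the scatter. Compound 3 is expected at 1300 nM, within 400 nM to 4000 nM, with a real chance that this assay returns only a limit. The expected step is therefore a 1.4-fold higher number from compound 2 to compound 3 (0.13 log units; within the scatter).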

Compound 3, half-maximal inhibitory concentration: 946 nM
The estimate for compound 3 lay 1.4-fold (0.14 log units) above the measured number, within the range that was stated.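

In this assay, the position para to a large group accepts chloro in place of nitro with a 1.0-fold lower number from compound 2 to compound 3 (0.01 log units; within the scatter), so a single chlorine serves here as well as the nitro with its 3 heavy atoms and 2 hydrogen-bond acceptors. The wider change of 4-chlorophenyl in place of 3-methylphenyl gives only a floor, an at least 1.0-fold lower number from compound 1 to compound 3 (0.02 log units; that floor lies within the scatter), and so shows no separation between these two aryl groups on the nitrogen. Compound 1 remains the only compound at a limit rather than a number: the limit of > 1000 nM in this assay, at which 1 of the 3 values shown sits.

The two groups at this position therefore give no trend, and the compounds shown do not tell whether any group placed there can move the number beyond the scatter. From the compounds shown here alone, whether an amine, a carboxylic acid or a longer chain at this place would do so remains open, as does the effect of replacing the bromo on the other aromatic ring.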